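Fluoro for chloro on two related cores

The source may report more compounds than this note shows. Statements on the series, on what has been measured and on what is new or still open speak of the compounds shown alone.

Measured compounds:
compound 1 `CCC1(CCCCN2CCN(c3ccc(F)cc3)CC2)C(=O)Nc2ccccc21`: 10 mg/kg
compound 3 `CCC1(CCCCN2CCN(c3ccc(Cl)cc3)CC2)C(=O)Nc2ccccc21`: 10 mg/kg
compound 2 `CCC1(CCCCN2CC=C(c3ccc(Cl)cc3)CC2)C(=O)Nc2ccccc21`: only a limit, > 20 mg/kg

In a functional assay on the whole organism (strain Wistar) with Rattus norvegicus as the target, with a stated time of 5 min (a higher number here means that more compound is needed for the effect, a lower number that less compound is needed), compound 1 gives 10 mg/kg and compound 3 gives 10 mg/kg. For compound 2 this assay reports only a limit, > 20 mg/kg. The change from compound 3 to compound 1 is fluoro in place of chloro on an aromatic carbon, and the step it made is no change at the digits printed from compound 3 to compound 1 (within the scatter). The difference between the core of compound 2 and the core of compound 3 is not broken down here. The same change, (fluoro in place of chloro on an aromatic carbon), leads from compound 2 to compound 4 `CCC1(CCCCN2CC=C(c3ccc(F)cc3)CC2)C(=O)Nc2ccccc21`, which has not yet been measured in this assay. Because the earlier step of no change at the digits printed from compound 3 to compound 1 (within the scatter) stayed within the scatter, the step that the limit leaves unreadable from compound 2 to compound 4 is expected to be small as well. Compound 4 is therefore expected near 30 mg/kg, between 15 mg/kg and 80 mg/kg, with a sizeable chance that this assay again reports only a limit.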

Compound 4, minimum effective dose: 20 mg/kg
Beside the measured number, compound 4's estimate is 1.5-fold (0.18 log units) above it; the range from low to high includes it.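

In this assay, fluoro in place of chloro on the core of compound 2 gives a number no higher from compound 2 to compound 4 (the limit leaves the size open). Set beside the same change on the core of compound 3, the two results read as follows: the same change on two cores in this assay, no change at the digits printed (within the scatter) from compound 3 to compound 1 and a number no higher (the limit leaves the size open) from compound 2 to compound 4; the limit leaves it open whether they differ. On both cores the change left the number no higher, but this does not show that the step has the same size on the two cores, since the value of compound 2 is only a limit: the limit of > 20 mg/kg in this assay, at which 1 of the 4 values shown sits.

The compounds shown leave open the size of the step on the core of compound 2. They also leave open what bromo or methoxy would do in place of chloro on the aromatic ring.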